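A few compounds are considered here, and "the series" means these few. Any claim that something is new, unique, unknown or untested is made for them only; others in the source may bear on it.

Compound 2 `CCc1csc(S(=O)(=O)NC(=O)Nc2ccc(Cl)cc2)c1` stands lowest of the two numbers in a functional assay on the whole organism (6C3HED cells, Mus musculus) for inhibition, at a dose of 150 mg/kg by the oral route (a higher number here means more inhibition at the dose given (going by the name of the read-out), a lower number less inhibition), giving 55%; its nearest neighbour, compound 1 `COc1ccc(S(=O)(=O)NC(=O)Nc2ccc(Cl)cc2)s1`, gives 93%, and the step of a number 38 percentage points lower from compound 1 to compound 2 (beyond the scatter) lies beyond the scatter. Compound 3 `Cc1cc(S(=O)(=O)NC(=O)Nc2ccc(Cl)cc2)sc1C` is unmeasured. Change: a group of 7 heavy atoms (6 carbon, 1 sulfur; one five-membered aromatic ring with 1 hetero atom) in place of a group of 7 heavy atoms (6 carbon, 1 sulfur; one five-membered aromatic ring with 1 hetero atom), on a sulfonyl sulfur. For the measured compounds named here, the only measured step bears on it loosely, as it exchanged ring atoms, whereas here the same atoms are joined differently; no measured pair shows this kind of change. The expected step of a number 5 percentage points higher from compound 2 to compound 3 (within the scatter) is therefore small, within the scatter, in either direction. Compound 3 is estimated at 60%, within 35% to 85%.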

Compound 3, a percentage reported as inhibition, in the whole organism at one dose (the size of the read-out at that dose, not a potency): 42%
Beside the measured number, compound 3's estimate is 18 percentage points above it; the measured number falls inside the stated range.
By their numbers in this assay, from the lowest: compound 3; then compound 2; then compound 1.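

In this assay the same atoms joined differently on a sulfonyl sulfur give a number 13 percentage points lower from compound 2 to compound 3 (beyond the scatter) and so the atom count of the group alone does not set the read-out. For the compounds shown here, putting 4,5-dimethylthiophen-2-yl in place of 5-methoxythiophen-2-yl gives a number 51 percentage points lower from compound 1 to compound 3 (beyond the scatter) and this is the first direct comparison of those two groups. Nothing at hand accounts for either step.

Still open, going by these compounds, is whether the higher number of compound 1 belongs to the methoxy group itself; an ethoxy group or a chlorine in that place would test this.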